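This account rests on a few compounds, and the source may have more. Where it says the series, first, only, none or still open, it means among the compounds named here.

Measured in an ADME assay on HEL cells (Homo sapiens) for cytotoxicity, with a stated time of 3 days; a higher number here means that more compound is tolerated, a lower number that less compound is tolerated:
- compound 1 `CCCCCCCCCCc1cc2cn([C@H]3C[C@H](O)[C@@H](CO)O3)c(=O)nc2o1` – > 510000 nM
- compound 2 `CCCCCc1ccc(C#Cc2cc3cn([C@H]4C[C@H](O)[C@@H](CO)O4)c(=O)nc3o2)cc1` – 110000 nM

Compound 1 stands at > 510000 nM, which is a limit of the assay and not a number. Compound 3 `CCCc1ccc(CCc2cc3cn([C@H]4C[C@H](O)[C@@H](CO)O4)c(=O)nc3o2)cc1` differs from compound 1 by having 4-propylphenyl in place of octyl on a saturated chain carbon, two bonds along the chain from an aromatic carbon. Among the measured compounds shown here, no measured pair isolates this change, so any expectation in this assay rests on thin ground. For the measured compounds named here, compound 2 is the only measured compound with a six-membered aromatic ring of carbon only in its side chain, and it gives 110000 nM. On that basis, less compound is expected to be tolerated, with an estimated at least 2.5-fold lower number from compound 1 to compound 3 (0.40 log units; beyond the scatter). For compound 3 the estimate is 200000 nM, with an expected range from 60000 nM to 510000 nM.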

Compound 3, half-maximal cytotoxic concentration: > 130000 nM
Compound 3: only a limit was reported; the forecaster's own chance of this, stated with the estimate: 35%; the middle value lies beyond the limit too.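

In this assay compound 1 and compound 3 are both reported as limits of the assay and not as numbers, so no step can be read between them. On these data alone, whether 4-propylphenyl in place of octyl changes how much compound is tolerated remains open.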